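Swapping the methoxyphenyl of compound 3 for a pyridyl

The source may hold more compounds than are shown below. What is called first, only, known or untested is meant among the compounds shown, and "the series" means these compounds.

Of the compounds shown here, three with a shared core have been tested in a functional assay on HL-60 cells (Homo sapiens) for cytotoxicity, read by WST assay, with a stated time of 48 h; a higher number here means a weaker inhibitor, a lower number a stronger inhibitor. Compound 1 `O[C@@H](c1ccccc1)[C@H]1CO[C@H](c2ccccc2)[C@@H](C/C=C/c2ccccn2)C1` gives 36400 nM. Compound 2 `COc1ccc(/C=C/C[C@@H]2C[C@@H]([C@@H](O)c3ccc(OC)c(OC)c3)CO[C@H]2c2ccc(OC)c(OC)c2)cc1OC` gives 26000 nM. Compound 3 `COc1cccc(/C=C/C[C@H]2C[C@@H]([C@@H](O)c3ccccc3)CO[C@@H]2c2ccccc2)c1` gives 9620 nM, the lowest of the three numbers; compound 2 sits nearest to it and compound 1 furthest, both beyond the scatter. Going by the values given here, the only single-place step among the measured compounds runs from the pyridin-2-yl of compound 1 to the 3-methoxyphenyl of compound 3 and reads a 3.8-fold lower number from compound 1 to compound 3 (0.58 log units; beyond the scatter), a modest move downward.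

Compound 4 `O[C@@H](c1ccccc1)[C@H]1CO[C@H](c2ccccc2)[C@@H](C/C=C/c2cccnc2)C1` is the next step from compound 3. pyridin-3-yl in place of 3-methoxyphenyl on a double-bonded chain carbon bound to a double-bonded chain carbon

The step from compound 1 to compound 3 bears directly on this change, since it also exchanges a pyridyl for the 3-methoxyphenyl, though the nitrogen now sits in a different place in the ring. That step lowered the number modestly, so reversing the exchange is expected to raise it by a similar amount, a step of a 2.6-fold higher number from compound 3 to compound 4 (0.41 log units; beyond the scatter). Compound 4 is therefore estimated at 25000 nM in this assay, with a range from 10000 nM to 70000 nM.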

Compound 4, half-maximal inhibitory concentration: > 100000 nM
Compound 4: only a limit was reported; the forecaster's own chance of this, stated with the estimate: 10%; middle value at least 4.0-fold (0.60 log units) away from the limit.
By their numbers in this assay, from the lowest: compound 3; then compounds 2 and 1 (each within the scatter of the next). At a limit, above all of these: compound 4.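

In this assay, compound 4 carries only a limit and not a number: the limit of > 100000 nM in this assay, at which 1 of the 4 values shown sits. Even so, exchanging 3-methoxyphenyl for pyridin-3-yl on a double-bonded chain carbon bound to a double-bonded chain carbon gives an at least 10-fold higher number from compound 3 to compound 4 (1.01 log units; beyond the scatter), a large step that shows this place tolerates the change far less well than the earlier pyridin-2-yl comparison alone suggested. Going by these compounds alone, the choice between the two pyridyl groups also counts here, which the earlier compounds could not show, since pyridin-3-yl in place of pyridin-2-yl gives an at least 2.7-fold higher number from compound 1 to compound 4 (0.43 log units; beyond the scatter), so the two are not interchangeable at this place in this assay.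

The compounds shown leave open how far compound 4 lies past its limit, so both new steps give only a lower bound on the change. They also leave open how a plain phenyl, a pyridin-4-yl or a 3-aminophenyl would read at this place, and so whether the sharp rise follows from the ring nitrogen of pyridin-3-yl or from losing the methoxy group of compound 3.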